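The source may hold more compounds than are shown below. What is called first, only, known or untested is meant among the compounds shown, and "the series" means these compounds.

Measured so far:
Compound 1, `CC(C)C[C@H](O)C(=O)NS(=O)(=O)OC[C@H]1O[C@@H](n2cnc3c(N)ncnc32)[C@H](O)[C@@H]1O`, gives 1760 nM in a functional assay on SK-HEP1 cells (Homo sapiens) for antiproliferative activity, read by sulforhodamine B assay, with a stated time of 72 h; on this read-out lower numbers stand for stronger inhibition and higher numbers for weaker inhibition.
Compound 2, `CC(C)[C@@H](O)[C@H](O)C(=O)NS(=O)(=O)OC[C@H]1O[C@@H](n2cnc3c(=O)[nH]cnc32)[C@H](O)[C@@H]1O`, gives only a limit in this assay, namely > 20000 nM.

Compound 2 thus stands at the limit of > 20000 nM in this assay, at which 1 of the 2 values shown sits; its value is a limit, not a number. Compound 3, `CC(C)C[C@H](O)C(=O)NS(=O)(=O)OC[C@H]1O[C@@H](n2cnc3c(=O)[nH]cnc32)[C@H](O)[C@@H]1O`, differs from compound 2 by one change: hydrogen in place of hydroxy on a saturated chain carbon bound to two saturated chain carbons. Among the compounds with values here, because compound 2 sits at the limit of > 20000 nM in this assay, at which 1 of the 2 values shown sits, no measured step sets the size here, only the direction can be expected. The isobutyl of compound 3 is also present in compound 1, and compound 1 gives 1760 nM. Compound 3 is therefore expected to gain, with an estimated step of an at least 2.5-fold lower number from compound 2 to compound 3 (0.39 log units; beyond the scatter), and an expected value of 8000 nM, in the range 2500 nM to 25000 nM.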

Compound 3, half-maximal inhibitory concentration: > 20000 nM
Compound 3 gave a limit, no number; the forecaster's own chance of this, stated with the estimate: 45%; middle value at least 2.5-fold (0.39 log units) from the limit.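

In this assay compound 3 also stays at a limit, so the exchange of 1-hydroxy-2-methylpropyl for isobutyl cannot be read from the two limits. Isobutyl alone thus gives no measurable number on this core. The isobutyl pair shows an at least 11-fold higher number from compound 1 to compound 3 (1.05 log units; beyond the scatter) when the group on the saturated ring carbon changes from five nitrogens in compound 1 to four nitrogens and an oxygen in compound 3. As far as these compounds go, the effect of the hydroxy on the chain with the ring group of compound 1 stays open. So does the effect of an amine or a longer chain at this place.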